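The compounds below may be only part of what the source reports. "The series", "measured", "known", "first", "only" and "open" are said of these compounds alone.

In a functional assay on SNU-5 cells (Homo sapiens) for inhibition, read by CCK-8 assay, with a stated time of 72 h (a lower number here means a stronger inhibitor, a higher number a weaker inhibitor), compound 1 `CNC(=O)c1ccc(-c2cnc3nnn(C(C)c4c(F)cc5ncc(-c6cnn(C)c6)cc5c4F)c3n2)cc1F` gives 0.9 nM, and compound 2 `CC(c1c(F)cc2ncc(-c3cnn(C)c3)cc2c1F)n1nnc2ncc(-c3ccncc3)nc21` gives 1.2 nM. Going by the values given here, the single measured step, a 1.3-fold higher number from compound 1 to compound 2 (0.12 log units; within the scatter), is the exchange of one aromatic substituent on a different aromatic carbon of the shared core. Among the compounds with values here, on the two numbers so far compound 2 stands at the higher of the two, with compound 1 as its only neighbour and the gap within the scatter, so no order between them is claimed.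

Compound 3 `CC(c1c(F)cc2ncc(-c3ccc(F)cc3)cc2c1F)n1nnc2ncc(-c3ccncc3)nc21` differs from compound 2 by 4-fluorophenyl in place of 1-methyl-1H-pyrazol-4-yl on an aromatic carbon. Within the data shown here, no measured step touches this position; the only step available, a 1.3-fold higher number from compound 1 to compound 2 (0.12 log units; within the scatter), shows that swapping one aryl group elsewhere left this assay unmoved beyond the scatter, but it carries no direct information on the present exchange. The expected step is therefore small and of uncertain direction, with wide bounds, a 2.1-fold higher number from compound 2 to compound 3 (0.32 log units; beyond the scatter). For compound 3 the estimate is 2.5 nM, with a range from 0.8 nM to 8 nM.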

Compound 3, half-maximal inhibitory concentration: 7.2 nM
Compound 3: middle estimate off by 2.9-fold (0.46 log units), on the low side; the range from low to high includes it.
By their numbers in this assay, from the lowest: compounds 1 and 2 (each within the scatter of the next); then compound 3.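

Going by these compounds alone, this is the first measured change at the position two atoms from the ring nitrogen, and in this assay replacing 1-methyl-1H-pyrazol-4-yl with 4-fluorophenyl gives a 6.0-fold higher number from compound 2 to compound 3 (0.78 log units; beyond the scatter). Within the data shown here, the number therefore depends on the group held here, whereas the one exchange at the other aryl position, a 1.3-fold higher number from compound 1 to compound 2 (0.12 log units; within the scatter), does not separate its two compounds. The leaving group carries 2 hydrogen-bond acceptors and the entering group 0, but no measurement links that difference, or any other, to the step.

The compounds shown do not separate the effect of exchanging the five-membered ring from that of the fluorine, which an unsubstituted phenyl or a morpholine at this position would help to test. On these data alone, it also remains open whether the step holds with 3-fluoro-4-(methylcarbamoyl)phenyl in place of pyridin-4-yl at the other position.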